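This account rests on a few compounds, and the source may have more. Where it says the series, first, only, none or still open, it means among the compounds named here.

Measured so far in a functional assay on LNCaP cells (Homo sapiens) for cytotoxicity; on this read-out higher numbers stand for weaker inhibition and lower numbers for stronger inhibition:
compound 1 `O=C(Nc1ccccc1)Nc1ccc(-c2nc(N3CC4CCC(C3)O4)c3cnn(C4CCC5(CC4)OCCO5)c3n2)cc1` gives 4 nM
compound 2 `O=C(Nc1ccncc1)Nc1ccc(-c2nc(N3CC4CCC(C3)O4)c3cnn(C4CCC5(CC4)OCCO5)c3n2)cc1` gives 1 nM
compound 3 `CNC(=O)Nc1ccc(-c2nc(N3CC4CCC(C3)O4)c3cnn(C4CCC5(CC4)OCCCO5)c3n2)cc1` gives 8 nM

Compound 2 holds the lowest number of the three, and both others lie beyond the scatter from it. Compound 4 `O=C(Nc1ccc(-c2nc(N3CC4CCC(C3)O4)c3cnn(C4CCC5(CC4)OCCO5)c3n2)cc1)NC1CC1` differs from compound 2 by cyclopropyl in place of pyridin-4-yl on an amide-type nitrogen. Among the compounds with values here, only one measured step bears on this change: a 4.0-fold lower number from compound 1 to compound 2 (0.60 log units; beyond the scatter), where pyridin-4-yl replaced phenyl. Within the data shown here, no measured compound carries cyclopropyl at this place. Losing pyridin-4-yl is therefore expected to give a modest rise in this assay, with an expected step of a 4.0-fold higher number from compound 2 to compound 4 (0.60 log units; beyond the scatter). Compound 4 is estimated at 4 nM, with an expected range from 1.5 nM to 12 nM.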

Compound 4, half-maximal inhibitory concentration: 2 nM
The estimate for compound 4 lay 2.0-fold (0.30 log units) above the measured number; the measured number falls inside the stated range.
By their numbers in this assay, from the lowest: compounds 2, 4, 1 and 3 (each within the scatter of the next, the first and the last beyond it).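

At this amide-type nitrogen, cyclopropyl, a three-membered non-aromatic ring of carbon only, can take the place of pyridin-4-yl in this assay with a 2.0-fold higher number from compound 2 to compound 4 (0.30 log units; within the scatter) as the only shift. Against phenyl it gives a 2.0-fold lower number from compound 1 to compound 4 (0.30 log units; within the scatter) so, among these compounds, a six-membered aromatic ring at this place is not needed for a low number. Nothing at hand explains this tolerance.

The compounds shown leave open how a longer chain such as butyl or a group carrying a carboxylic acid would fare on this nitrogen. They also leave open whether an amine on the ring would keep the number this low.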